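Phenyl or cyclopentyl on the amine nitrogen

The source may hold more compounds than are shown below. What is called first, only, known or untested is meant among the compounds shown, and "the series" means these compounds.

Measured in a functional assay on MCF7 cells (Homo sapiens) for inhibition, read by sulforhodamine B assay; a lower number here means a stronger inhibitor, a higher number a weaker inhibitor:
- Compound 1 `CCCc1ccc(NC2=CC(=O)c3nc4n(c3C2=O)[C@H]2OC[C@@H](O)[C@H]2OC4)cc1`: 4660 nM
- Compound 2 `O=C1C=C(NC2CCCC2)C(=O)c2c1nc1n2[C@H]2OC[C@@H](O)[C@H]2OC1`: > 16000 nM, a limit and not a number

Compound 2 stands at the limit of > 16000 nM in this assay, at which 1 of the 2 values shown sits. It therefore offers a limit to start from, not a number.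

Compound 3 `O=C1C=C(Nc2ccc(C(F)(F)F)cc2)C(=O)c2c1nc1n2[C@H]2OC[C@@H](O)[C@H]2OC1` shares the core of compound 2 and changes one group, 4-(trifluoromethyl)phenyl in place of cyclopentyl on an amine nitrogen.

Among the compounds with values here, one measured step bears on this change: an at least 3.4-fold higher number from compound 1 to compound 2 (0.53 log units; beyond the scatter). There, cyclopentyl replaces 4-propylphenyl at the same place, so the new change runs the opposite way and puts a substituted phenyl ring back on that nitrogen. Within the data shown here, no measured compound yet carries 4-(trifluoromethyl)phenyl, and the comparison rests on a single pair, so the size stays uncertain.

A step of comparable size towards a lower number in this assay is expected on the strength of an at least 3.4-fold higher number from compound 1 to compound 2 (0.53 log units; beyond the scatter). The expected step is an at least 2.6-fold lower number from compound 2 to compound 3 (0.42 log units; beyond the scatter).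

The estimate for compound 3 is 6000 nM, with an expected range of 2000 nM to 16000 nM.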

Compound 3, half-maximal inhibitory concentration: > 4000 nM
Compound 3: a limit, no number; the forecaster's own chance of this, stated with the estimate: 20%; the middle value does not contradict the limit.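

In this assay compound 3 gives > 4000 nM, a limit and not a number. Neither the step from compound 2 to compound 3 nor the step from compound 1 to compound 3 can be read. The compounds shown leave open how 4-(trifluoromethyl)phenyl on the amine nitrogen ranks against cyclopentyl and 4-propylphenyl.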